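Methyl on the aromatic ring of compound 1: expected step

The source may report more compounds than this note shows. Statements on the series, on what has been measured and on what is new or still open speak of the compounds shown alone.

In a functional assay on Bel-7402 cells (Homo sapiens) for cytotoxicity, read by MTT assay, with a stated time of 72 h (a lower number here means a stronger inhibitor, a higher number a weaker inhibitor), compound 1 `O=C1C=CCC/C1=C\C=C\c1ccccc1` gives 4200 nM and compound 2 `CC(=C\c1ccccc1)/C=C1\CCC=CC1=O` gives 3900 nM. These two numbers lie within the scatter of each other, so compound 1 stands level with compound 2.

Compound 3 `O=C1C=CCC/C1=C\C(Br)=C\c1ccccc1` gives > 10000 nM, which is a limit of the assay and not a number.

The next compound is compound 4 `Cc1ccc(/C=C/C=C2\CCC=CC2=O)cc1`. It carries methyl in place of hydrogen on an aromatic carbon of the six-membered aromatic ring, para to a large group (methyl in place of hydrogen on an aromatic carbon). Going by the values given here, no measured step touches that ring, so all the guidance is indirect.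

Among the compounds with values here, the closest precedent is methyl in place of hydrogen on a double-bonded chain carbon, which gave a 1.1-fold lower number from compound 1 to compound 2 (0.03 log units; within the scatter). Bromo on that same chain carbon gave an at least 2.3-fold higher number from compound 1 to compound 3 (0.37 log units; beyond the scatter), and bromo in place of methyl there gave an at least 2.5-fold higher number from compound 2 to compound 3 (0.40 log units; beyond the scatter). Both bromo steps are at least modest, but they involve a different group at a different place, so they carry less weight here.

With the methyl precedent as the guide, no step beyond the scatter is expected in this assay. The estimated step is a 1.1-fold lower number from compound 1 to compound 4 (0.02 log units; within the scatter). For compound 4 the expected value is 4000 nM, with an estimated range of 1800 nM to 9000 nM.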

Compound 4, half-maximal inhibitory concentration: 6300 nM
Compound 4: middle estimate off by 1.6-fold (0.20 log units), on the low side, and the stated range covers the measured number.
By their numbers in this assay, from the lowest: compounds 2, 1 and 4 (each within the scatter of the next). At a limit, above all of these: compound 3.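

Going by these compounds alone, on the six-membered aromatic ring, para to a large group, methyl in place of hydrogen gives a 1.5-fold higher number from compound 1 to compound 4 (0.18 log units; within the scatter) in this assay; this is the first reading at this ring, as all earlier steps sat on a double-bonded chain carbon. Methyl has now been read at two places, and the chain carbon gives a similar outcome, with a 1.1-fold lower number from compound 1 to compound 2 (0.03 log units; within the scatter), so at neither place does this small change move the number beyond the scatter. The only steps beyond the scatter remain those to the bromo compound, and compound 3 stands at a limit of the assay, not at a number: the limit of > 10000 nM in this assay, at which 1 of the 4 values shown sits.

Going by these compounds, what the ring position does with anything other than methyl stays open: an amine, a carboxylic acid or a longer chain there could behave quite differently, and a single methyl step says little about them. On these data alone, whether bromo on the aromatic carbon would follow the chain-carbon result also stays open, as does whether any change at this position can give a clearly lower number than compound 1 shows.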